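A few compounds are considered here, and "the series" means these few. Any claim that something is new, unique, unknown or untested is made for them only; others in the source may bear on it.

Three related compounds were tested in a functional assay on OVCAR-3 cells (Homo sapiens) for antiproliferative activity, read by MTT assay, with a stated time of 24 h; on this read-out lower numbers stand for stronger inhibition and higher numbers for weaker inhibition. Compound 1 `Cc1ccccc1NNC(=O)c1ccc(NS(=O)(=O)c2cnc(O)nc2O)cc1` is reported there only as a limit, > 20000 nM. Compound 2 `O=C(NNc1cccc(Cl)c1)c1ccc(NS(=O)(=O)c2cnc(O)nc2O)cc1` gives 8410 nM, and compound 3 `O=C(NNc1ccccc1Cl)c1cccc(NS(=O)(=O)c2cnc(O)nc2O)c1` gives 3350 nM. That is the lowest number of the set, and the nearest, that of compound 2, is higher by a gap beyond the scatter.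

Compound 4 `O=C(NNc1ccc(F)cc1)c1cccc(NS(=O)(=O)c2cnc(O)nc2O)c1` keeps the core of compound 3 and differs only in the group on an amine nitrogen: 4-fluorophenyl in place of 2-chlorophenyl on an amine nitrogen. Going by the values given here, one measured step bears on this place, an at least 2.3-fold lower number from compound 1 to compound 2 (0.37 log units; beyond the scatter), where 3-chlorophenyl replaced 2-methylphenyl. That step starts from a limit, so it fixes only a smallest size, and it was measured on the core of compound 1 rather than that of compound 3. It is therefore a weak guide. Compound 4 gives up the chlorophenyl group carried by both compounds with a measured number, so a modest rise in this assay is expected rather than a fall, although a result within the scatter remains possible. The expected change is a 1.8-fold higher number from compound 3 to compound 4 (0.25 log units; within the scatter). For compound 4 the estimated value is 6000 nM, with an expected range from 2200 nM to 18000 nM.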

Compound 4, half-maximal inhibitory concentration: > 20000 nM
Compound 4 was reported as a limit; the forecaster's own chance of this, stated with the estimate: 20%; at least 3.3-fold (0.52 log units) between middle value and limit.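

Going by these compounds alone, replacing 2-chlorophenyl with 4-fluorophenyl on an amine nitrogen gives an at least 5.9-fold higher number from compound 3 to compound 4 (0.77 log units; beyond the scatter) in this assay, so this place matters on the core of compound 3, where the only earlier step at this place could not speak, as it was measured on another core. Carrying a halogen on the phenyl ring is also not enough to hold the number of compound 3 in this assay, even though the two groups are alike in what is counted: each is a six-membered aromatic ring of carbon only with no hydrogen-bond donors or acceptors. Compound 4 is reported only as a limit, > 20000 nM, so the step gives a smallest size and its full size stays unknown, and that ceiling recurs in this set: the limit of > 20000 nM in this assay, at which 2 of the 4 values shown sit.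

Whether the rise follows the exchange of chlorine for fluorine or the different place of the halogen on the ring cannot be separated, as this one step changes both at once. As far as these compounds go, how a plain phenyl group, or a phenyl ring bearing an amine or a carboxylic acid, would read at this place remains open.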